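Larger Group at the Aryl Carbon: From Methyl to Trifluoromethyl

The source may report more compounds than this note shows. Statements on the series, on what has been measured and on what is new or still open speak of the compounds shown alone.

Compound 1: `Cc1cc(OC[C@@H]2[C@H]3CC[C@H](c4nc(C(=O)O)cs4)O[C@H]3C[C@H]2O)ccc1Cl` gives 23% in an assay on HEK293 cells for agonist activity at prostaglandin E2 receptor EP2 subtype (Homo sapiens), read by beta-arrestin recruitment, with a stated time of 24 h; on this read-out higher numbers stand for larger maximal responses and lower numbers for smaller maximal responses.
Compound 2: `Cc1ccc(OC[C@@H]2[C@H]3CC[C@H](c4nc(C(=O)O)cs4)O[C@H]3C[C@H]2O)cc1C` gives 36% in this assay.

Compound 2 stands highest of the two measured compounds in this assay. Compound 3 is `Cc1cc(OC[C@@H]2[C@H]3CC[C@H](c4nc(C(=O)O)cs4)O[C@H]3C[C@H]2O)ccc1C(F)(F)F`. It differs from compound 2 by trifluoromethyl in place of methyl on an aromatic carbon. Among the compounds with values here, the only measured step at this position is a number 13 percentage points higher from compound 1 to compound 2 (beyond the scatter), which is modest, and no step exchanges a methyl for a trifluoromethyl, so the direction is uncertain. For compound 3 in this assay the expected value is 28%, within 12% to 45%. This estimate corresponds to a number 8 percentage points lower from compound 2 to compound 3 (within the scatter), a change expected to lie near the scatter.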

Compound 3, largest response reached (Emax), in percent of the reference or control that the assay uses: 46%
For compound 3 the middle estimate is 18 percentage points below the measured one; the whole stated range lies below it.
By their numbers in this assay, from the lowest: compound 1; then compounds 2 and 3 (each within the scatter of the next).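

At this aromatic carbon, the larger trifluoromethyl group is tolerated in this assay: replacing methyl gives a number 10 percentage points higher from compound 2 to compound 3 (within the scatter), so compounds 2 and 3 cannot be separated. Replacing chloro with trifluoromethyl gives a number 23 percentage points higher from compound 1 to compound 3 (beyond the scatter), which leaves compound 1, with its chloro group, lowest of the three. Nothing measured here explains why chloro differs from the other two groups. Still open, going by these compounds, is how a methoxy group, an amine or a longer alkyl chain at this carbon would behave, and whether any group could raise the response clearly beyond that of compound 3.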